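The source may hold more compounds than are shown below. What is called first, only, known or untested is meant among the compounds shown, and "the series" means these compounds.

Of the compounds shown here, two that share one core have been tested in a functional assay on MCF7 cells (Homo sapiens) for antiproliferative activity, read by MTT assay; a lower number here means a stronger inhibitor, a higher number a weaker inhibitor. Compound 1 `NS(=O)(=O)c1ccc(/N=C2\NC(=O)/C(=C3/C(=O)N(Cc4ccccc4)c4ccc(Cl)cc43)S2)cc1` gives 124000 nM in this assay. Compound 2 `CN1C(=O)/C(=C2\S/C(=N/c3ccc(S(N)(=O)=O)cc3)NC2=O)c2cc(Br)ccc21` gives 196000 nM in this assay, the highest of the two numbers shown, although compound 1, its nearest neighbour, lies within the usual scatter of it, so the two values cannot be told apart. Within the data shown here, compound 2 and compound 1 differ in more than one place, so their two numbers give no single step to lean on. Compound 3 `NS(=O)(=O)c1ccc(/N=C2\NC(=O)/C(=C3/C(=O)N(Cc4ccccc4)c4ccc(Br)cc43)S2)cc1` is the next to be measured and differs from compound 2 in one place: phenyl in place of hydrogen on a saturated chain carbon bound to an amide-type nitrogen in a ring. Compound 1 already carries that benzyl group, and its value 124000 nM in this assay sits close to that of compound 2, so there is little reason to expect a large shift from adding it. The step expected here is a 1.4-fold lower number from compound 2 to compound 3 (0.15 log units; within the scatter), which amounts to no change beyond the scatter. Compound 3 is therefore expected to give 140000 nM in this assay, within a range from 50000 nM to 400000 nM.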

Compound 3, half-maximal inhibitory concentration: > 200000 nM
Compound 3 ended at the assay's limit; the forecaster's own chance of this, stated with the estimate: 20%; at least 1.4-fold (0.15 log units) between middle value and limit.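

In this assay compound 3 gives > 200000 nM, which is a limit of the assay and not a number, and the reading of this compound stops there: the limit of > 200000 nM in this assay, at which 1 of the 3 values shown sits.

The change from methyl to benzyl, on a saturated chain carbon bound to an amide-type nitrogen in a ring, gives an at least 1.0-fold higher number from compound 2 to compound 3 (0.00 log units; that floor lies within the scatter), and bromo in place of chloro on an aromatic carbon gives an at least 1.6-fold higher number from compound 1 to compound 3 (0.20 log units; that floor lies within the scatter). Each of these is only a floor, so the true steps may be larger, but neither can be a lower number, which means that with bromo on the aromatic carbon the benzyl group brings no sign of a stronger inhibitor than methyl.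

The compounds shown leave open whether another group in this place, such as an ethyl chain or a benzyl carrying an amine on its aromatic ring, would bring the number down, and whether fluoro on the aromatic carbon would differ from chloro or bromo. Going by these compounds, how far compound 3 truly lies from compound 1 and compound 2 also stays unknown, since only a floor can be read for it.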